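The compounds below may be only part of what the source reports. "The series", "measured", "known", "first", "only" and "open" are said of these compounds alone.

Working notes on the series. Compound 2 `COc1cc(C2=NN(C(C)=O)C(c3c(Cl)cccc3Cl)O2)cc(OC)c1OC` sits second highest of the three numbers in a functional assay on PC-3 cells (Homo sapiens) for antiproliferative activity, read by MTT assay, tested at 1 uM (a higher number here means a stronger effect of the compound at the concentration tested, a lower number a weaker effect), giving 5.1%; compound 1 `COc1cc(C2=NN(C(C)=O)C(c3ccccc3C(F)(F)F)O2)cc(OC)c1OC` gives -11%, and compound 3 `COc1cc(C(=O)N/N=C/c2cccc(F)c2)cc(OC)c1OC`, with a different core, gives 53.5%. Among the measured compounds shown here, the one measured step within the shared core, a number 16.1 percentage points higher from compound 1 to compound 2 (beyond the scatter), is modest. Compound 4 `COc1cc(C2=NN(C(C)=O)C(c3ccc(Cl)c(Cl)c3)O2)cc(OC)c1OC` differs from compound 2 by 3,4-dichlorophenyl in place of 2,6-dichlorophenyl on a saturated ring carbon. For the measured compounds named here, no measured step moves chlorine around the same ring, so the direction is open; the only comparison available is the modest step from compound 1 to compound 2, which offers no clear guide. Compound 4 is therefore expected near compound 2, with the step of a number 4.9 percentage points higher from compound 2 to compound 4 (within the scatter) estimated to stay within the scatter. The estimate for compound 4 is 10%, from -15% to 35%.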

Compound 4, a percentage reported as inhibition, at one concentration (the size of the read-out at that concentration, not a potency): 28.1%
For compound 4 the middle estimate is 18.1 percentage points below the measured one, within the range that was stated.
By their numbers in this assay, from the lowest: compound 1; then compound 2; then compound 4; then compound 3.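

In this assay, the same two chlorines on the same phenyl ring give a different read-out once rearranged: 3,4-dichlorophenyl in place of 2,6-dichlorophenyl gives a number 23 percentage points higher from compound 2 to compound 4 (beyond the scatter) and shows that this position responds to the substitution pattern alone. Replacing 2-(trifluoromethyl)phenyl with 3,4-dichlorophenyl gives a number 39.1 percentage points higher from compound 1 to compound 4 (beyond the scatter) and is a large change at the same carbon. Nothing available explains either step.

Still open, on these data alone, is how the shared core reads with an unsubstituted phenyl, or with a phenyl bearing a single chlorine or an amine. As far as these compounds go, the read-out at other concentrations also remains open.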